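This account rests on a few compounds, and the source may have more. Where it says the series, first, only, none or still open, it means among the compounds named here.

Measured compounds:
compound 1, `CC(C)S(=O)(=O)NC(=O)c1ccc(Nc2nc(NC3(c4ccc(Cl)cc4)CC3)nc(OCC(F)(F)F)n2)cc1`, 31 nm/s in a physicochemical assay for permeability, using PAMPA, at pH 7.4; on this read-out higher numbers stand for higher permeability and lower numbers for lower permeability
compound 2, `CC(C)C(=O)NCCS(=O)(=O)NC(=O)c1ccc(Nc2nc(NC3(c4ccc(Cl)cc4)CC3)nc(OCC(F)(F)F)n2)cc1`, 13 nm/s in this assay
compound 3, `CCS(=O)(=O)NC(=O)c1ccc(Nc2nc(NC3(c4ccc(Cl)cc4)CC3)nc(OCC(F)(F)F)n2)cc1`, 28 nm/s in this assay

Compound 3 stands second of the three in this assay, close to compound 1 and clearly apart from compound 2. The unmeasured compound 4, `O=C(NS(=O)(=O)CCNC(=O)C1CC1)c1ccc(Nc2nc(NC3(c4ccc(Cl)cc4)CC3)nc(OCC(F)(F)F)n2)cc1`, differs from compound 3 in one place: (cyclopropylcarbonyl)amino in place of hydrogen on a saturated chain carbon, two bonds along the chain from a sulfonyl sulfur. Within the data shown here, two measured steps bear on this change. The step of a 2.2-fold higher number from compound 2 to compound 3 (0.33 log units; beyond the scatter) removes a (isopropylcarbonyl)amino group from the same chain position, and the step of a 2.4-fold lower number from compound 1 to compound 2 (0.38 log units; beyond the scatter) adds the same group onto the sulfonyl substituent. Both point the same way: the longer, amide-bearing chain gives a modestly lower number. Compound 4 carries a closely related (cyclopropylcarbonyl)amino group at the same position, so a modest drop in this assay is expected. For compound 4 the expected step is a 2.2-fold lower number from compound 3 to compound 4 (0.33 log units; beyond the scatter), and its estimate in this assay is 13 nm/s, with a range from 6 nm/s to 28 nm/s.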

Compound 4, apparent permeability: 1 nm/s
For compound 4 the middle estimate is 13-fold (1.11 log units) above the measured one; the measured number lies below the stated range.
By their numbers in this assay, from the lowest: compound 4; then compound 2; then compounds 3 and 1 (each within the scatter of the next).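

In this assay the (cyclopropylcarbonyl)amino group, on a saturated chain carbon two bonds along the chain from a sulfonyl sulfur, brings a 28-fold lower number from compound 3 to compound 4 (1.45 log units; beyond the scatter) and also a 31-fold lower number from compound 1 to compound 4 (1.49 log units; beyond the scatter) in place of the short sulfonyl substituents, large steps where compound 2 had shown only modest ones. Most striking is a 13-fold lower number from compound 2 to compound 4 (1.11 log units; beyond the scatter) for cyclopropyl in place of isopropyl on a carbonyl carbon alone, so the amide-bearing chain by itself does not set the number and the group on that carbonyl counts heavily. No measurement at hand accounts for this gap.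

The compounds shown leave open whether the drop belongs to cyclopropyl itself or would recur with cyclobutyl or tert-butyl on the carbonyl. They also leave open whether a chain ending in a simple amine or a methyl ether would sit nearer compound 2 or compound 4.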